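Swapping the oxazole for a pyrazole on the amide side chain

The source may hold more compounds than are shown below. What is called first, only, known or untested is meant among the compounds shown, and "the series" means these compounds.

Compound 1, `Cc1cc(C(C)NC(=O)c2[nH]cc(Cc3ccc(C(F)(F)F)nc3)c2C)no1`, is the compound on which the available numbers rest. In an ADME assay on microsomes from liver (Homo sapiens) for metabolic stability, read by LC-MS, with a stated time of 4 h, tested at 1 uM (on this read-out higher numbers stand for fast clearance and lower numbers for slow clearance), compound 1 gives 60000 mL.min-1.g-1. Among the measured compounds shown here, that is the only actual number available. Compound 2, `Cc1cc(Nc2ccc(S(F)(F)(F)(F)F)cc2)n2nc(C(F)(F)F)nc2n1`, belongs to a different chemical family and is not a close relative of compound 1. In this assay compound 2 gives < 25000 mL.min-1.g-1, which is a limit of the assay, as the limit of < 25000 mL.min-1.g-1 in this assay, at which 1 of the 2 values shown sits, records. Compound 3, `Cc1c(Cc2ccc(C(F)(F)F)nc2)c[nH]c1C(=O)NC(C)c1cn[nH]c1`, keeps the core of compound 1 and changes one group: 1H-pyrazol-4-yl in place of 5-methyl-1,2-oxazol-3-yl on a saturated chain carbon bound to an amide-type nitrogen and a saturated chain carbon. For the measured compounds named here, no step between two measured compounds of this kind is available, so the effect of this change can only be estimated. The change is expected to bring a modest fall in this assay, a step of a 1.9-fold lower number from compound 1 to compound 3 (0.27 log units; within the scatter), though a result within the usual scatter of compound 1 would not be surprising. On that basis compound 3 is estimated at 32000 mL.min-1.g-1, with a likely range from 12000 mL.min-1.g-1 to 75000 mL.min-1.g-1.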

Compound 3, intrinsic clearance in microsomes in the Homo sapiens assay: 33000 mL.min-1.g-1
Estimate against measurement, compound 3: 1.0-fold (0.01 log units) below; the measured number falls inside the stated range.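

In the Homo sapiens assay the change gives a 1.8-fold lower number from compound 1 to compound 3 (0.26 log units; within the scatter), so the two compounds cannot be told apart on clearance, and replacing 5-methyl-1,2-oxazol-3-yl with 1H-pyrazol-4-yl on this saturated chain carbon leaves that read-out within its normal noise. In a physicochemical assay for solubility, with a stated time of 1 h, at pH 1.6 (on this read-out higher numbers stand for higher solubility and lower numbers for lower solubility), compound 1 gives 35.1 ug/mL and compound 3 gives 81 ug/mL. In the physicochemical assay the same change gives a 2.3-fold higher number from compound 1 to compound 3 (0.36 log units; beyond the scatter), so this one swap separates the two compounds on this second read-out, whereas the clearance step stays within the scatter.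

The swap changes the ring atoms and removes the methyl group in a single move, so these two compounds cannot show which part of the change accounts for the step. From the compounds shown here alone, it also remains open how other groups on this saturated chain carbon, such as a plain phenyl ring or a carboxylic acid, would behave on either read-out, since one replacement at one place says little about the range of groups this position can carry.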